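The source may hold more compounds than are shown below. What is called first, only, known or untested is meant among the compounds shown, and "the series" means these compounds.

Three compounds built on one shared core have been run through an assay on CHO cells for displacement of a labelled ligand from adenosine receptor A3 (Homo sapiens), read by scintillation counting, with a stated time of 60 min, tested at 1 uM; on this read-out lower numbers stand for less inhibition and higher numbers for more inhibition at the one concentration tested (going by the name of the read-out). Compound 1 `COc1ccc(-c2nc3cn(C)nc3c(=O)[nH]2)cc1` carries a methoxy group on its phenyl ring and gives 1% in this assay. Compound 3 `Cn1cc2nc(-c3ccccc3)nc(N)c2n1` carries an unsubstituted phenyl ring and an amino group in place of the carbonyl of compound 1; in this assay compound 3 gives 1%, and the two numbers are level at the digits shown and together are the lowest of the three. Compound 2 `O=c1[nH]c(-c2ccco2)nc2cn(-c3ccccc3)nc12` carries a different set of groups and gives 30% in this assay, a number higher than that of compound 1 by more than the scatter. No single change links compound 2 to compound 1, so its higher number cannot be traced to one group.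

Compound 4 `Cn1cc2nc(-c3ccccc3)[nH]c(=O)c2n1` has not yet been measured. It differs from compound 1 in one place: hydrogen in place of methoxy on an aromatic carbon. Among the measured compounds shown here, no pair of measured compounds shows what this change does here. The closest hint is compound 3, which also carries an unsubstituted phenyl ring and gives 1%, though its core differs elsewhere. Because compound 1 gives 1% and compound 3 gives 1%, compound 4 is expected to stay near the bottom of the range, with a step of a number 3 percentage points higher from compound 1 to compound 4 (within the scatter) that is expected to lie within the scatter. The estimate for compound 4 is 4%, with a range from 0% to 18%.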

Compound 4, a percentage reported as inhibition, at one concentration (the size of the read-out at that concentration, not a potency): 20%
Compound 4: the middle estimate sits 16 percentage points below what was measured; the measured number lies above the stated range.
By their numbers in this assay, from the lowest: compounds 1 and 3 (each within the scatter of the next); then compounds 4 and 2 (each within the scatter of the next).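

Among the compounds shown here, replacing methoxy with hydrogen on the aromatic carbon para to a large group gives a number 19 percentage points higher from compound 1 to compound 4 (beyond the scatter) in this assay, the first change in this set that can be tied to one place on the molecule. It shows that this position is not indifferent to what it carries, although compound 3, which also has hydrogen there, gives 1% while compound 4 gives 20%, so hydrogen at this place does not bring the higher number on every version of the core. Nothing measured here accounts for the step, and the reason for it remains unknown.

A single pair cannot show whether it is the loss of methoxy that matters most or how far the number depends on what replaces it, and a fluorine atom, a hydroxyl group or a longer ethoxy chain at the same place would help to separate these readings. On these data alone, it also remains open whether the same swap would give a similar step on other versions of the core, and a number taken at one concentration says nothing direct about potency.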